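The source may report more compounds than this note shows. Statements on the series, on what has been measured and on what is new or still open speak of the compounds shown alone.

Compound 3 `CCOc1ccc(-c2cccc(C(=O)NC)c2)cc1` carries a methylcarbamoyl group on the shared core. In an assay on COS-7 cells for inhibition of patatin-like phospholipase domain-containing protein 2 (Mus musculus) (on this read-out higher numbers stand for weaker inhibition and lower numbers for stronger inhibition), compound 3 gives only a limit, > 200000 nM. Compound 1 `CCOc1ccc(-c2cccc(S(=O)(=O)NC)c2)cc1`, which carries methylsulfamoyl in place of methylcarbamoyl, gives 200000 nM in this assay. Compound 2 `CCOc1ccc(-c2cccc(C(=O)OCCOCCOC)c2)cc1` gives a limit in this assay, > 200000 nM. The step of a number no lower from compound 1 to compound 3 (the limit leaves the size open) and the step that the two limits leave unreadable from compound 2 to compound 3 are both of unreadable size, so compound 3 stands among values that cannot be separated from one another; the limit of > 200000 nM in this assay, at which 2 of the 3 values shown sit, covers two of the three values shown. Compound 4 `CCNC(=O)c1cccc(-c2ccc(OCC)cc2)c1` differs from compound 3 by methyl in place of hydrogen on a saturated chain carbon bound to an amide-type nitrogen. Among the measured compounds shown here, no measured step touches the substituent on the amide nitrogen; the two steps that reach compound 3 alter other parts of the molecule and neither has a readable size, so none bears directly on this change. The step of a number no higher from compound 3 to compound 4 (the limit leaves the size open) is expected to be none beyond the scatter. Compound 4 is therefore expected at 200000 nM, within a range from 100000 nM to 400000 nM, and most likely reported again only as a limit.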

Compound 4, half-maximal inhibitory concentration: 90000 nM
Beside the measured number, compound 4's estimate is 2.2-fold (0.35 log units) above it; the whole stated range lies above it.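

Lengthening the group on the amide nitrogen, from methylcarbamoyl to ethylcarbamoyl, is the first change in the series with a readable effect in this assay: an at least 2.2-fold lower number from compound 3 to compound 4 (0.34 log units; beyond the scatter). Ethylcarbamoyl also separates from the other two groups, with an at least 2.2-fold lower number from compound 2 to compound 4 (0.34 log units; beyond the scatter) against 2-(2-methoxyethoxy)ethoxy on the carbonyl carbon and a 2.2-fold lower number from compound 1 to compound 4 (0.35 log units; beyond the scatter) against methylsulfamoyl, the last being the only one of these steps with a number at both ends. The first two sizes are lower bounds only, and the steps among compound 1, compound 2 and compound 3 cannot be read: the limit of > 200000 nM in this assay, at which 2 of the 4 values shown sit.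

As far as these compounds go, how far the effect runs along this chain stays open, since a propyl or longer chain on the amide nitrogen, or one ending in an amine, could extend it or reverse it. The true size of the step from the methylcarbamoyl group also stays unfixed.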